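The source may report more compounds than this note shows. Statements on the series, on what has been measured and on what is new or still open speak of the compounds shown alone.

Among the compounds with values here, in an ADME assay on HeLa cells (Homo sapiens) for cytotoxicity, with a stated time of 72 h (a higher number here means that more compound is tolerated, a lower number that less compound is tolerated), compound 1 (`COc1ccc(/C=C\c2cc(OC)c(OC)c(OC)c2)cc1NC(=O)[C@H](C)NC(=O)[C@H](CCCNC(=N)N)NC(=O)[C@H](CCCCN)NC(=O)c1ccccc1`) gives 24.6 nM, the lower of the two numbers measured so far. Compound 2 (`COc1ccc(/C=C\c2cc(OC)c(OC)c(OC)c2)cc1NC(=O)CCNC(=O)[C@H](CCCNC(=N)N)NC(=O)[C@H](CCCNC(=N)N)NC(=O)c1ccccc1`) gives 952 nM, a gap well beyond the usual scatter of repeat measurements. These two compounds differ in more than one place, so the gap cannot be tied to any single change.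

Compound 3 (`COc1ccc(/C=C\c2cc(OC)c(OC)c(OC)c2)cc1NC(=O)[C@H](C)NC(=O)[C@H](CCCNC(=N)N)NC(=O)[C@H](CCCNC(=N)N)NC(=O)c1ccccc1`) stays much closer to compound 1, with a single edit: a group of 4 heavy atoms (1 carbon, 3 nitrogen; no ring) in place of a group of 2 heavy atoms (1 carbon, 1 nitrogen; no ring), on a saturated chain carbon, four bonds along the chain from an amide-type nitrogen and a carbonyl carbon. In words, a group of 4 heavy atoms replaces a group of 2 heavy atoms, on a saturated chain carbon, four bonds along the chain from an amide-type nitrogen and a carbonyl carbon.

Within the data shown here, no measured pair shows this edit on its own, so there is no direct precedent for its size. Compound 2 at 952 nM shows only that higher numbers occur among these compounds, so a small upward move is expected, perhaps not beyond the scatter. The estimated step is a 1.6-fold higher number from compound 1 to compound 3 (0.21 log units; within the scatter). For compound 3 the expected value is 40 nM, with an estimated range of 12 nM to 200 nM.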

Compound 3, half-maximal cytotoxic concentration: 65.7 nM
The estimate for compound 3 lay 1.6-fold (0.22 log units) below the measured number; measured number inside the range.
By their numbers in this assay, from the lowest: compound 1; then compound 3; then compound 2.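

Within the data shown here, until now, no pair of compounds isolated a single change at this spot, so nothing showed whether this saturated chain position mattered in this assay. Replacing aminomethyl with the group of 4 heavy atoms gives a 2.7-fold higher number from compound 1 to compound 3 (0.43 log units; beyond the scatter), so the change is a real but modest shift towards more compound being tolerated, with the end of this side chain as the only structural difference. The entering group has more hydrogen-bond donors and one double bond outside aromatic rings, but no measurement here connects either feature to the higher number or explains the shift.

This single pair cannot show whether the same swap would produce a similar shift on the other side chain or in a compound with a different remaining structure. It also leaves open how the number would respond at this position to a carboxylic acid, a hydroxyl group or a longer chain ending in an amine, so no trend can yet be drawn for this site.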